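Adding a second methoxymethyl group to compound 3

The source may hold more compounds than are shown below. What is called first, only, known or untested is meant among the compounds shown, and "the series" means these compounds.

This account follows a small series of compounds tested in a functional assay on MIA PaCa-2 cells (Homo sapiens) for antiproliferative activity, read by MTT assay, with a stated time of 72 h; on this read-out lower numbers stand for stronger inhibition and higher numbers for weaker inhibition. Compound 1 `O=c1cc(CC(O)(COCc2ccccc2)COCc2ccccc2)[nH]c(=O)[nH]1` reaches only a limit of the assay, > 100000 nM. Compound 2 `COCn1c(CC(COCc2ccccc2)COCc2ccccc2)cc(=O)[nH]c1=O` likewise reaches only a limit, > 100000 nM. Among the measured compounds shown here, compound 3 `COCn1c(CC(COCc2ccccc2)COCc2ccccc2)c(C)c(=O)[nH]c1=O` stands apart as the only member of the series with a definite number, giving 55900 nM in this assay. The other two entries remain limits of the assay. For the measured compounds named here, the single measured step, an at least 1.7-fold lower number from compound 2 to compound 3 (0.25 log units; that floor lies within the scatter), replaces a hydrogen on an aromatic carbon with a methyl; its size cannot be fixed beyond the scatter because of the limit of > 100000 nM in this assay, at which 2 of the 3 values shown sit.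

Compound 4 `COCn1c(CC(COCc2ccccc2)COCc2ccccc2)c(C)c(=O)n(COC)c1=O` is not yet measured. It differs from compound 3 by methoxymethyl in place of hydrogen on an aromatic nitrogen. Going by the values given here, no measured step places a methoxymethyl on the second ring nitrogen, and the only step available, the methyl addition from compound 2 to compound 3, did not clearly move the number beyond the scatter. With nothing in the series pointing in either direction, compound 4 is expected to show no step beyond the scatter, a 1.1-fold higher number from compound 3 to compound 4 (0.03 log units; within the scatter). Compound 4 is therefore estimated at 60000 nM in this assay, with a range from 20000 nM to 150000 nM, and a real chance that only a limit is reported.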

Compound 4, half-maximal inhibitory concentration: 500 nM
For compound 4 the middle estimate is 120-fold (2.08 log units) above the measured one; the whole stated range lies above it.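

In this assay, among the compounds shown here, methoxymethyl in place of hydrogen on the aromatic nitrogen gives a 110-fold lower number from compound 3 to compound 4 (2.05 log units; beyond the scatter), the first step that lies beyond the scatter. This shows that the number responds strongly at this ring nitrogen, para to a large group and meta to the methoxymethyl group already present, while compounds 1, 2 and 3 all keep a hydrogen there. The only earlier step, the methyl on an aromatic carbon, cannot be sized against this one, because its floor rests on a limit: the limit of > 100000 nM in this assay, at which 2 of the 4 values shown sit.

The compounds shown leave open whether the effect belongs to methoxymethyl itself, or whether a plain methyl, an ethyl or a longer chain ending in an amine on the same nitrogen would move the number in the same way. They also leave open whether the methyl on the ring carbon is needed for the step, since the second methoxymethyl appears here only together with that methyl, and whether a hydroxyl on the side chain, as in compound 1, would be tolerated alongside both methoxymethyl groups.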